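The source may report more compounds than this note shows. Statements on the series, on what has been measured and on what is new or still open speak of the compounds shown alone.

Within the data shown here, compound 2 `NC(=O)c1c(NC(=O)c2ccccc2Cl)sc2c1CCN(C(=O)Nc1ccccc1Cl)C2` is the one member of the series with a numerical result: in a functional assay on HL-60 cells (Homo sapiens) for antiproliferative activity, with a stated time of 24 h (on this read-out lower numbers stand for stronger inhibition and higher numbers for weaker inhibition), compound 2 gives 12500 nM. Compound 1 `NC(=O)c1c(NC(=O)c2ccc(C(F)(F)F)cc2)sc2c1CCN(Cc1ccc(Cl)cc1)C2` returns only a limit in this assay, > 50000 nM. Among the measured compounds shown here, the only other value in the set is the limit of > 50000 nM in this assay, at which 1 of the 2 values shown sits. Compound 2 is therefore the sole numerical point from which to work. Compound 3 `NC(=O)c1c(NC(=O)c2ccc(C(F)(F)F)cc2)sc2c1CCN(C(=O)Nc1ccccc1Cl)C2` has not been measured; it differs from compound 2 by 4-(trifluoromethyl)phenyl in place of 2-chlorophenyl on a carbonyl carbon. For the measured compounds named here, no measured pair follows this change on its own, so the size of the step cannot be read off directly. Compound 1 carries the same 4-(trifluoromethyl)phenyl amide and gave only a limit, > 50000 nM. On that basis a loss beyond the scatter is expected, a 2.4-fold higher number from compound 2 to compound 3 (0.38 log units; beyond the scatter). Compound 3 is estimated at 30000 nM in this assay, within 8000 nM to 100000 nM, with a real chance that only a limit is reported.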

Compound 3, half-maximal inhibitory concentration: > 50000 nM
Compound 3: a limit, no number (the forecaster's own chance of this, stated with the estimate: 45%); at least 1.6-fold (0.22 log units) between middle value and limit.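

With the (2-chlorophenyl)carbamoyl group on the amine nitrogen in the ring held fixed, the exchange of 2-chlorophenyl for 4-(trifluoromethyl)phenyl on a carbonyl carbon can now be followed on its own, and it gives an at least 4.0-fold higher number from compound 2 to compound 3 (0.60 log units; beyond the scatter). Compound 1 and compound 3 both carry 4-(trifluoromethyl)phenyl at this place, and neither yields a number, only an assay limit: the limit of > 50000 nM in this assay, at which 2 of the 3 values shown sit. The step between these two compounds cannot be read, so the group on the ring nitrogen shows no readable effect alongside this amide.

From the compounds shown here alone, the true size of the loss stays open, as does any value for compound 3 beyond its limit. Also open, going by these compounds, is whether a plain phenyl, a 2-methoxyphenyl or a 2-aminophenyl on this carbonyl carbon would match or improve on 2-chlorophenyl.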